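The source may hold more compounds than are shown below. What is called first, only, known or untested is meant among the compounds shown, and "the series" means these compounds.

Measured so far in an ADME assay on HEK293 cells (Homo sapiens) for cytotoxicity, read by CellTiter-Glo and resazurin assay, with a stated time of 72 h; a higher number here means that more compound is needed for the effect, a lower number that less compound is needed:

Compound 1, `CC(C)N(Cc1cccc(OCCCCCC(=O)O)c1)C(=O)c1ccc(-c2cccc(N(C)C)c2)cc1`. In this assay compound 1 gives > 26000 nM, a limit of the assay and not a number.
Compound 2, `CC(C)N(Cc1cccc(OCCCCCC(=O)O)c1)C(=O)c1ccc(-c2cccc(-c3ccccc3)c2)cc1`. In this assay compound 2 gives > 26000 nM, again a limit of the assay.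
Compound 3, `CC(C)N(Cc1cccc(OCCCCCC(=O)O)c1)C(=O)c1ccc(-c2ccc3[nH]ccc3c2)cc1`. In this assay compound 3 gives > 26000 nM, which is also a limit of the assay.

Compound 3 therefore stands at the ceiling of this assay, and so do both of its neighbours, all three sitting at the limit of > 26000 nM in this assay, at which 3 of the 3 values shown sit. The steps among them, a step that the two limits leave unreadable from compound 1 to compound 2, a step that the two limits leave unreadable from compound 1 to compound 3 and a step that the two limits leave unreadable from compound 2 to compound 3, are unreadable for that reason, and none of them shows a measurable change of cytotoxicity despite the groups exchanged on the shared core.

Compound 4, `CCOc1cccc(-c2ccc(C(=O)N(Cc3cccc(OCCCCCC(=O)O)c3)C(C)C)cc2)c1`, differs from compound 3 in one place: 3-ethoxyphenyl in place of 1H-indol-5-yl on an aromatic carbon. All three measured steps bear on this change in the sense that each swaps the group at the same position, and each left the value at the limit. The author therefore expects no step beyond the scatter, with a step that the limit leaves unreadable from compound 3 to compound 4 as the estimated step, and most likely a further limit. The estimate for compound 4 in this assay is 40000 nM, with a range from 20000 nM to 200000 nM.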

Compound 4, half-maximal effective concentration: > 20800 nM
Compound 4 gave a limit, no number; the forecaster's own chance of this, stated with the estimate: 85%; the middle value does not contradict the limit.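

In this assay compound 4 gives > 20800 nM, a limit of the assay and not a number. Its steps to compound 1, compound 2 and compound 3 therefore cannot be read. The compounds shown leave open whether the groups exchanged on the shared core differ in cytotoxicity at all.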